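The source may hold more compounds than are shown below. What is called first, only, known or untested is meant among the compounds shown, and "the series" means these compounds.

Compound 1 `Nc1nc(Cl)c2ncn(Cc3ccccc3CCl)c2n1` was tested in a functional assay on SNB-75 cells (Homo sapiens) for cytotoxicity, read by sulforhodamine B assay, with a stated time of 48 h (a lower number here means a stronger inhibitor of growth, a higher number a weaker inhibitor of growth), and gave 23500 nM. Among the three compounds measured so far it holds the second highest number. Compound 3 `ClCc1ccccc1Cn1cnc2ncnc(Cl)c21` gives 26900 nM in this assay, and this number and that of compound 1 lie within the scatter of repeated measurements, so the two cannot be told apart. Compound 2 `ClCc1cccc(Cn2cnc3nc(Cl)nc(Cl)c32)c1` gives 2290 nM in this assay, a number well below that of compound 1 and outside the scatter.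

Compound 4 `ClCc1ccccc1Cn1cnc2c(Cl)ncnc21` has not yet been measured. It differs from compound 1 in one place: hydrogen in place of amino on an aromatic carbon. The amino group on the six-membered aromatic ring of the shared core is replaced by hydrogen.

Among the measured compounds shown here, no measured pair shows the effect of this exact change, so the expectation rests on the numbers at hand. Because compound 1 gives 23500 nM and compound 3 gives 26900 nM in this assay, both in the same weak range, no step beyond the scatter is expected, and the step from compound 1 to compound 4 is estimated at a 1.1-fold higher number from compound 1 to compound 4 (0.03 log units; within the scatter). Compound 4 is therefore expected to give about 25000 nM in this assay, most likely between 10000 nM and 60000 nM.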

Compound 4, concentration for total growth inhibition: 11000 nM
Compound 4: the middle estimate sits 2.3-fold (0.36 log units) above what was measured; the range from low to high includes it.
By their numbers in this assay, from the lowest: compound 2; then compound 4; then compounds 1 and 3 (each within the scatter of the next).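

Among the compounds shown here, replacing the amino group with hydrogen on the aromatic carbon between two ring nitrogen atoms gives the first step that can be read at this position: in this assay, it is a 2.1-fold lower number from compound 1 to compound 4 (0.33 log units; beyond the scatter) and counts as modest. In this pair, the amino group is therefore not required for growth inhibition, and compound 4 is the stronger of the two without it. This is one pair of compounds, and no measurement shown gives a reason for the step.

From the compounds shown here alone, it remains open whether a methylamino group, a methoxy group or a fluoro group on this carbon would give a number closer to that of compound 1 or that of compound 4 in this assay. Going by these compounds, it also remains open whether the same change would give a step of similar size in compounds with other groups elsewhere on the shared core.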